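Nitrostyryl-fluorophenyl cyclohexanone pair: chloro for fluoro

This account rests on a few compounds, and the source may have more. Where it says the series, first, only, none or still open, it means among the compounds named here.

Measured so far in a functional assay on L1210 cells (Mus musculus) for cytotoxicity, with a stated time of 48 h; a higher number here means a weaker inhibitor, a lower number a stronger inhibitor:
compound 1, `O=C1/C(=C/c2ccc(F)cc2)CCC/C1=C\c1cccc([N+](=O)[O-])c1`, gives 16300 nM;
compound 2, `O=C1/C(=C/c2ccc(F)cc2)CCC/C1=C\c1ccccc1[N+](=O)[O-]`, gives 8400 nM;
compound 3, `O=C1/C(=C/c2ccc(Cl)cc2)CCC/C1=C\c1ccccc1[N+](=O)[O-]`, gives 9380 nM.

Compound 2 and compound 3 share one core and differ only by chloro in place of fluoro on an aromatic carbon; the measured step is a 1.1-fold higher number from compound 2 to compound 3 (0.05 log units; within the scatter). Compound 1 and compound 2 have the same atoms joined differently; the difference between the two cores is not broken down here, and their values sit close together in this assay.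

The unmeasured compound 4, `O=C1/C(=C/c2ccc(Cl)cc2)CCC/C1=C\c1cccc([N+](=O)[O-])c1`, stands to compound 1 as compound 3 stands to compound 2: it differs by chloro in place of fluoro on an aromatic carbon, the place line reading word for word as for the pair already measured, so the change is the same one seen there.

For the measured compounds named here, the expectation for compound 1 to compound 4 in this assay is therefore a step of about a 1.1-fold higher number from compound 1 to compound 4 (0.04 log units; within the scatter), resting on the single measured instance a 1.1-fold higher number from compound 2 to compound 3 (0.05 log units; within the scatter), which stayed within the scatter. On that basis compound 4 is estimated at 18000 nM in this assay, with a range from 9000 nM to 36000 nM.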

Compound 4, half-maximal inhibitory concentration: 9160 nM
Compound 4: the middle estimate sits 2.0-fold (0.29 log units) above what was measured; measured number inside the range.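

In this assay, the exchange of 4-fluorophenyl for 4-chlorophenyl gives a 1.8-fold lower number from compound 1 to compound 4 (0.25 log units; within the scatter), so on this second core the step again stays within the usual scatter. Set beside the earlier instance, the two steps do not differ beyond what repeated measurement allows: the same change on two cores in this assay, a 1.1-fold higher number (0.05 log units; within the scatter) from compound 2 to compound 3 and a 1.8-fold lower number (0.25 log units; within the scatter) from compound 1 to compound 4, 2.0-fold (0.30 log units) apart, within the scatter of two such steps. Chloro in place of fluoro can therefore be carried between these two cores as a change with no readable effect on the number in this assay, but this rests on two pairs only, cannot separate a small real effect from scatter, and does not show that the same would hold on other cores or in other assays.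

The compounds shown leave open whether a different group at this place, such as bromo, methoxy, an amine or a carboxylic acid, would move the number beyond the scatter. Also open, from the compounds shown here alone, is whether the exchange would behave alike with the nitro group replaced, for example by a nitrile or an amine.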